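The source may report more compounds than this note shows. Statements on the series, on what has been measured and on what is new or still open speak of the compounds shown alone.

In a physicochemical assay for solubility, measured as kinetic solubility (a higher number here means a more soluble compound, a lower number a less soluble compound), compound 1, whose structure is `O=C(Nc1ccnnc1)c1cc(N2CCNCC2)ccc1OCc1ccccc1`, gives 98000 nM. Among the two compounds with an actual number in this assay, compound 1 stands highest; its nearest neighbour is compound 2, `CN1CCC(c2ccc(OCc3ccccc3)c(C(=O)Nc3ccnnc3)c2)CC1`, which gives 71000 nM. That step, a 1.4-fold lower number from compound 1 to compound 2 (0.14 log units; within the scatter), keeps a piperazin-1-yl or a 1-methylpiperidin-4-yl group on the same carbon of the shared core and changes little. A third compound, compound 3 with structure `O=C(Nc1cccnc1)c1cc(C(F)(F)F)ccc1OCc1ccccc1`, is different in kind: for it this assay reports only a limit, < 1000 nM, and not a number. That compound carries a trifluoromethyl group.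

The next compound, compound 4 with structure `O=C(Nc1ccnnc1)c1cc(C(F)(F)F)ccc1OCc1ccccc1`, differs from compound 1 in one place: trifluoromethyl in place of piperazin-1-yl on an aromatic carbon. Among the measured compounds shown here, no measured step covers this exact change. For the measured compounds named here, the only measured step, from compound 1 to compound 2, is within the scatter and swaps one ring for another, so it says little about losing the ring altogether. What bears on the change is the limit of < 1000 nM in this assay, at which 1 of the 3 values shown sits, which belongs to the one trifluoromethyl compound shown. Because of the limit of < 1000 nM in this assay, at which 1 of the 3 values shown sits, a large drop is expected for compound 4, of about a 49-fold lower number from compound 1 to compound 4 (1.69 log units; beyond the scatter), quite possibly down to a limit. Compound 4 is therefore estimated at 2000 nM, with a range from 400 nM to 12000 nM.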

Compound 4, solubility: < 1000 nM
Compound 4: only a limit was reported; the forecaster's own chance of this, stated with the estimate: 50%; middle value at least 2.0-fold (0.30 log units) away from the limit.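

In this assay, keeping the pyridazin-4-yl amide is not enough to keep the number high: at this aromatic carbon, para to the benzyloxy group, the swap to trifluoromethyl gives an at least 98-fold lower number from compound 1 to compound 4 (1.99 log units; beyond the scatter), and the same swap starting from the 1-methylpiperidin-4-yl group gives an at least 71-fold lower number from compound 2 to compound 4 (1.85 log units; beyond the scatter). Among the compounds shown here, until now the only trifluoromethyl compound, compound 3, also differed from compound 1 at the amide nitrogen, so its low result could not be tied to one place, whereas compound 4 differs from compound 1 and compound 2 only at this carbon, and its result is a limit, so both steps give only a minimum size. Compound 3 and compound 4 are both limits, so the step between them cannot be read, and the low end of the series now holds both trifluoromethyl compounds: the limit of < 1000 nM in this assay, at which 2 of the 4 values shown sit.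

As far as these compounds go, how far compound 4 really lies beyond its limit stays open, as does any effect of pyridazin-4-yl against pyridin-3-yl on the amide nitrogen. A morpholine ring, an open-chain amine such as dimethylamino or a carboxylic acid on this same carbon would help show whether the high numbers depend on an amine nitrogen, on a ring, or on neither.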